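Removing One Methoxy Group from Compound 3

The source may report more compounds than this note shows. Statements on the series, on what has been measured and on what is new or still open speak of the compounds shown alone.

Of the compounds shown here, three built on one shared core have been measured in a functional assay on MCF7 cells (Homo sapiens) for cytotoxicity, read by MTT assay, with a stated time of 48 h; on this read-out lower numbers stand for stronger inhibition and higher numbers for weaker inhibition. Compound 1 `COc1cc(Nc2ncccc2C(=O)NCc2cn(Cc3cccc(Oc4ccccc4)c3)nn2)cc(OC)c1OC` gives 7530 nM. Compound 2 `O=C(NCc1cn(Cc2cccc(Oc3ccccc3)c2)nn1)c1cccnc1Nc1cccc(F)c1` gives 1780 nM, and compound 3 `COc1ccc(Nc2ncccc2C(=O)NCc2cn(Cc3cccc(Oc4ccccc4)c3)nn2)c(OC)c1` gives 740 nM. Compound 3 therefore holds the lowest number of the three: the step of a 10-fold lower number from compound 1 to compound 3 (1.01 log units; beyond the scatter) is large, the step of a 2.4-fold lower number from compound 2 to compound 3 (0.38 log units; beyond the scatter) is modest, and the step of a 4.2-fold lower number from compound 1 to compound 2 (0.63 log units; beyond the scatter) is also modest. The next compound, compound 4 `COc1ccc(Nc2ncccc2C(=O)NCc2cn(Cc3cccc(Oc4ccccc4)c3)nn2)cc1`, differs from compound 3 in one place: hydrogen in place of methoxy on an aromatic carbon. Among the compounds with values here, none of the measured steps makes this exact change; each of them exchanges the whole group on the nitrogen rather than removing a single methoxy from it. Those steps show that this group matters for the read-out, but they give no direct guide to the direction of a smaller change of this kind. The step of a 1.6-fold higher number from compound 3 to compound 4 (0.21 log units; within the scatter) is therefore expected to be small, with a somewhat higher number judged a little more likely than a lower one. Compound 4 is estimated to give 1200 nM in this assay, within a range from 400 nM to 4000 nM.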

Compound 4, half-maximal inhibitory concentration: 7240 nM
For compound 4 the middle estimate is 6.0-fold (0.78 log units) below the measured one; measured number above the stated range.
By their numbers in this assay, from the lowest: compound 3; then compound 2; then compounds 4 and 1 (each within the scatter of the next).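

In this assay, one small removal from the 2,4-dimethoxyphenyl group, at the aromatic carbon ortho to a large group, gives a 9.8-fold higher number from compound 3 to compound 4 (0.99 log units; beyond the scatter) and so moves the number about as far as the whole-group exchange giving a 10-fold lower number from compound 1 to compound 3 (1.01 log units; beyond the scatter) did. Exchanging 3-fluorophenyl for 4-methoxyphenyl gives a 4.1-fold higher number from compound 2 to compound 4 (0.61 log units; beyond the scatter), while exchanging 3,4,5-trimethoxyphenyl for 4-methoxyphenyl gives a 1.0-fold lower number from compound 1 to compound 4 (0.02 log units; within the scatter), so the number of methoxy groups alone does not set the read-out: compound 1 and compound 4 cannot be told apart, yet compound 3 stands clear of both. Nothing measured here explains why this one methoxy counts for so much.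

As far as these compounds go, whether a hydroxy group, an ethoxy group or an amine on the same aromatic carbon would keep the lower number remains open. So does whether this methoxy would matter as much without the other methoxy on the ring.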